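This account rests on a few compounds, and the source may have more. Where it says the series, first, only, none or still open, it means among the compounds named here.

Three compounds share one core, with an amide on one side and a substituted benzyl amide on the other. Compound 1 `COc1ccc(CNC(=O)CSc2nc3ccc(NC(C)=O)cc3s2)cc1` gives in a functional assay on MCF7 cells (Homo sapiens) for cytotoxicity, read by MTT assay, with a stated time of 48 h (a higher number here means a weaker inhibitor, a lower number a stronger inhibitor), a value of 20500 nM. For the measured compounds named here, compound 2 `COc1ccc(CNC(=O)CSc2nc3ccc(NC(=O)CCl)cc3s2)cc1` carries a chloro on the saturated chain carbon bound to a carbonyl carbon, and in this assay compound 2 gives 5100 nM; the step of a 4.0-fold lower number from compound 1 to compound 2 (0.60 log units; beyond the scatter) is the only measured step in this set. Compound 3 `O=C(CSc1nc2ccc(NC(=O)c3ccc([N+](=O)[O-])cc3)cc2s1)NCc1ccc(Cl)cc1` carries a different amide and a 4-chlorobenzyl group. In this assay compound 3 reaches only a limit of the assay, > 100000 nM. Compound 3 thus sits at the limit of > 100000 nM in this assay, at which 1 of the 3 values shown sits, so no number is known for it. Compound 4 `COc1ccc(CNC(=O)CSc2nc3ccc(NC(=O)c4ccc([N+](=O)[O-])cc4)cc3s2)cc1` is the unmeasured partner; the change is methoxy in place of chloro on an aromatic carbon. Going by the values given here, no measured step covers this change, so the step of a 4.0-fold lower number from compound 1 to compound 2 (0.60 log units; beyond the scatter) does not bear on it. Compound 1 and compound 2 both carry the 4-methoxybenzyl group with other amides and show numbers rather than limits. For compound 4 a weak result is expected, around 90000 nM within a range from 20000 nM to 300000 nM. This expectation corresponds to a step of an at least 1.1-fold lower number from compound 3 to compound 4 (0.04 log units; that floor lies within the scatter).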

Compound 4, half-maximal inhibitory concentration: > 100000 nM
Compound 4 ended at the assay's limit (the forecaster's own chance of this, stated with the estimate: 55%); middle value at least 1.1-fold (0.04 log units) away from the limit.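

With the 4-methoxybenzyl group held fixed in this assay, the amide on the other side of the core clearly matters: 4-nitrophenyl in place of chloromethyl on the carbonyl carbon gives a large loss (an at least 19-fold higher number from compound 2 to compound 4 (1.29 log units; beyond the scatter)), and 4-nitrophenyl in place of methyl gives a loss of at least modest size (an at least 4.8-fold higher number from compound 1 to compound 4 (0.68 log units; beyond the scatter)). The weak result of compound 3 therefore need not be tied to its 4-chlorobenzyl group, since compound 4 lacks that group and still stays at the limit. The swap of chloro for methoxy itself cannot be read, since compound 3 and compound 4 both give a limit rather than a number: the limit of > 100000 nM in this assay, at which 2 of the 4 values shown sit.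

On these data alone, whether that swap changes anything alongside the smaller amides of compound 1 and compound 2 stays open. Also open, as far as these compounds go, is how the 4-nitrophenyl amide would behave with an amine or a carboxylic acid in place of the nitro group.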